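The compounds below may be only part of what the source reports. "The series", "measured", "known", "first", "only" and "open" are said of these compounds alone.

Working notes on the series. Two compounds have numbers in an assay on microsomes from liver for inhibition of sterol O-acyltransferase 1 (Rattus norvegicus) (a lower number here means a stronger inhibitor, a higher number a weaker inhibitor), so far. Compound 1 `CCCCCCCCOc1cc(-c2ccccc2)c(-c2ccccc2)nn1` gives 104000 nM in this assay, and compound 2 `CCCCCCSc1cc(-c2ccccc2)c(-c2ccccc2)nn1` gives 62000 nM. Among the compounds with values here, the one step between them, hexylsulfanyl in place of octyloxy on an aromatic carbon, moved the number a 1.7-fold lower number from compound 1 to compound 2 (0.22 log units; within the scatter), so compound 2 stands with the lower of the two numbers but not apart from compound 1 beyond the scatter.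

Compound 3 `CCCCCCCSc1cc(-c2ccccc2)c(-c2ccccc2)nn1` is not yet measured. It differs from compound 2 by methyl in place of hydrogen on a saturated chain carbon, six bonds along the chain from a sulfur. Within the data shown here, no measured step touches the length of the saturated chain alone; the only step on record, from compound 1 to compound 2, changes the chain and the linking atom together and stays within the scatter. On that basis no step beyond the scatter is expected in this assay, with a slight lean toward a lower number, giving an expected 1.2-fold lower number from compound 2 to compound 3 (0.09 log units; within the scatter). Compound 3 is therefore estimated at 50000 nM in this assay, within a range of 20000 nM to 130000 nM.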

Compound 3, half-maximal inhibitory concentration: 76000 nM
Compound 3: middle estimate off by 1.5-fold (0.18 log units), on the low side, and the stated range covers the measured number.
By their numbers in this assay, from the lowest: compounds 2, 3 and 1 (each within the scatter of the next).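

In this assay, within the data shown here, methyl in place of hydrogen on a saturated chain carbon, six bonds along the chain from a sulfur, gives a 1.2-fold higher number from compound 2 to compound 3 (0.09 log units; within the scatter) and is the first step that alters the saturated chain alone. At this chain end, the added methyl therefore does not separate the two compounds beyond the scatter. Exchanging the octyloxy chain for a heptylsulfanyl chain gives a 1.4-fold lower number from compound 1 to compound 3 (0.14 log units; within the scatter) and, like the earlier exchange, stays within the scatter; nothing on hand offers an explanation for these small steps.

The compounds shown leave open whether a much longer chain, such as dodecylsulfanyl, or a carboxylic acid at the chain end would give a step beyond the scatter. The effect of sulfur against oxygen alone also remains unread, as both exchanges alter the chain and the linking atom together.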